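A Further Methoxy on a Weak Compound

A few compounds are considered here, and "the series" means these few. Any claim that something is new, unique, unknown or untested is made for them only; others in the source may bear on it.

- Compound 1 `COc1cc(OC)c(OC)cc1/C=C/C(=O)/C=C/c1cc2ccccc2nc1Cl`: 1810 nM
- Compound 2 `COc1ccc(/C=C/C(=O)/C=C/c2cc3ccccc3nc2Oc2ccccc2)c(OC)c1`: > 10000 nM (a limit, not a number)
- Compound 3 `COc1ccc(/C=C/C(=O)/C=C/c2cc3ccccc3nc2Oc2ccccc2)cc1OC`: > 10000 nM (a limit, not a number)

In a functional assay on 4T1 cells (Mus musculus) for cytotoxicity, read by MTT assay, with a stated time of 48 h (a higher number here means a weaker inhibitor, a lower number a stronger inhibitor), compound 3 stands at > 10000 nM, which is a limit and not a number. This is the limit of > 10000 nM in this assay, at which 2 of the 3 values shown sit.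

Compound 4 `COc1cc(OC)c(OC)cc1/C=C/C(=O)/C=C/c1cc2ccccc2nc1Oc1ccccc1` differs from compound 3 by one change, methoxy in place of hydrogen on an aromatic carbon.

Among the measured compounds shown here, the only measured step of a similar kind is a step that the two limits leave unreadable from compound 2 to compound 3, so it offers no size to carry over. Compound 4 shares its methoxy pattern with compound 1, which gives 1810 nM. The two differ elsewhere on the core, however, so this is only a weak hint that compound 4 could show a readable value.

The expected change is small or unreadable, and any shift is expected towards a stronger inhibitor: a number no higher from compound 3 to compound 4 (the limit leaves the size open). Compound 4 is estimated at 10000 nM, with an expected range of 4000 nM to 25000 nM.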

Compound 4, half-maximal inhibitory concentration: 7630 nM
The estimate for compound 4 lay 1.3-fold (0.12 log units) above the measured number; low and high end bracket the measured number.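

The added methoxy, ortho to a large group, gives compound 4 a readable number, the only one among the phenoxy compounds shown. Its gain can only be stated as a floor, and that floor stays within the scatter: an at least 1.3-fold lower number from compound 3 to compound 4 (0.11 log units; that floor lies within the scatter), and in the same way an at least 1.3-fold lower number from compound 2 to compound 4 (0.11 log units; that floor lies within the scatter). Among the compounds shown here, the readable number also allows the first sized comparison of phenoxy with chloro on the same methoxy pattern, a 4.2-fold higher number from compound 1 to compound 4 (0.62 log units; beyond the scatter), while the other phenoxy compounds stay at a limit: the limit of > 10000 nM in this assay, at which 2 of the 4 values shown sit.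

On these data alone, the true size of the methoxy step remains open, as its starting points are limits and not numbers. Also open, as far as these compounds go, is how an amine or a carboxylic acid would compare with chloro and phenoxy on that aromatic carbon of the shared core.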